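Aryl Amine Variation on a Pyrimidine Urea Series

The compounds below may be only part of what the source reports. "The series", "measured", "known", "first", "only" and "open" are said of these compounds alone.

Measured compounds:
- compound 1 `COc1cc(NC(=O)Nc2cc(Nc3ccc(C)c(C)c3)ncn2)cc(OC)c1`: 66%
- compound 2 `Cc1cc(F)cc(Nc2cc(NC(=O)Nc3c(Cl)cccc3Cl)ncn2)c1`: 80%
- compound 3 `COc1cc(Nc2cc(NC(=O)Nc3c(Cl)cccc3Cl)ncn2)cc(OC)c1`: 90%

Three compounds were tested in a functional assay on PC-9 cells (Homo sapiens) for inhibition, read by MTT assay, with a stated time of 48 h, tested at 10 uM; on this read-out lower numbers stand for less inhibition and higher numbers for more inhibition at the one concentration tested (going by the name of the read-out). Compound 1 stands lowest of the three; compound 2 sits above it by a gap beyond the scatter, and compound 3 sits higher still, also beyond the scatter. Among the compounds with values here, compounds 2 and 3 differ from compound 1 in more than one place, so their values show only that the numbers of compound 2 and compound 3 in this assay are higher than that of compound 1.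

Compound 4 `COc1cc(NC(=O)Nc2cc(Nc3cc(I)ccc3OC)ncn2)cc(OC)c1` has not yet been measured. It differs from compound 1 in one place: 5-iodo-2-methoxyphenyl in place of 3,4-dimethylphenyl on a nitrogen on an aromatic ring. Within the data shown here, no pair of measured compounds isolates this change, so the direction of its effect is not established by the data. Compound 4 is expected to give a value near that of compound 1, with the step of a number 4 percentage points lower from compound 1 to compound 4 (within the scatter) estimated to lie within the scatter. Compound 4 is therefore estimated at 62%, with a range from 38% to 86%.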

Compound 4, a percentage reported as inhibition, at one concentration (the size of the read-out at that concentration, not a potency): 91%
Compound 4: the middle estimate sits 29 percentage points below what was measured; the whole stated range lies below it.
By their numbers in this assay, from the lowest: compound 1; then compounds 2, 3 and 4 (each within the scatter of the next, the first and the last beyond it).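

In this assay, putting 5-iodo-2-methoxyphenyl in place of 3,4-dimethylphenyl on a nitrogen on an aromatic ring gives a number 25 percentage points higher from compound 1 to compound 4 (beyond the scatter), the first single-place step available here, and it shows that the number responds to what this nitrogen carries. The entering group brings iodine, oxygen and one hydrogen-bond acceptor at once, so this one step cannot show which of these features goes with the higher number. No measured information explains the step.

The compounds shown leave open whether a phenyl ring carrying only the iodo group or only the methoxy group would give the same result. They also leave open how a group of another kind, such as a morpholine or a carboxylic acid, would read at this place.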